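A few compounds are considered here, and "the series" means these few. Any claim that something is new, unique, unknown or untested is made for them only; others in the source may bear on it.

In a functional assay on PC-9 cells (Homo sapiens) for inhibition, read by MTT assay, with a stated time of 72 h (a higher number here means a weaker inhibitor, a lower number a stronger inhibitor), compound 1 `Cc1cc(Nc2cc(-c3ccccc3)[nH]n2)n2nc(SCc3ccc(F)cc3)nc2n1` gives 8110 nM while compound 3 `Cc1cc(Nc2cc(-c3ccccc3)[nH]n2)n2nc(SCc3ccc(Br)cc3)nc2n1` gives 4760 nM and compound 2 `Cc1cc(Nc2ccn(Cc3cccc4ccccc34)n2)n2nc(SCc3ccc(Br)cc3)nc2n1` gives 5660 nM on the same scale. Compound 2 therefore stands within the scatter of both other compounds, and the three numbers cannot be ranked.

Compound 4 `Cc1cc(Nc2ccn(Cc3ccc(F)cc3)n2)n2nc(SCc3ccc(Br)cc3)nc2n1` has not yet been measured. It differs from compound 2 by 4-fluorophenyl in place of naphthalen-1-yl on a saturated chain carbon bound to an aromatic nitrogen and by nothing else.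

Within the data shown here, the only measured single change is a 1.7-fold lower number from compound 1 to compound 3 (0.23 log units; within the scatter) and it comes from bromo in place of fluoro on an aromatic carbon, which is a different change from this one. Among the measured compounds shown here, no measured step replaces naphthalen-1-yl, so the data give no direction for it. Compound 2 and compound 3 differ in more than one place, yet their values lie within the scatter of each other. Taking compound 2 at 5660 nM as the anchor, no step beyond the scatter is expected in this assay and neither direction is favoured.

The expected change is a 1.1-fold higher number from compound 2 to compound 4 (0.03 log units; within the scatter) and it remains only an estimate. For compound 4 the estimated value is 6000 nM with an expected range from 2500 nM to 14000 nM on this reckoning.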

Compound 4, half-maximal inhibitory concentration: 19400 nM
Compound 4: the middle estimate sits 3.2-fold (0.51 log units) below what was measured; the whole stated range lies below it.
By their numbers in this assay, from the lowest: compounds 3, 2 and 1 (each within the scatter of the next); then compound 4.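

In this assay, going from (naphthalen-1-yl)methyl to 4-fluorobenzyl gives a 3.4-fold higher number from compound 2 to compound 4 (0.53 log units; beyond the scatter), a modest step in favour of the naphthalen-1-yl group, and it shows that the group on a saturated chain carbon bound to an aromatic nitrogen can move the number beyond the scatter, which the bromo and fluoro exchange, at a 1.7-fold lower number from compound 1 to compound 3 (0.23 log units; within the scatter), did not do. Among these compounds, the single change is really several at once: two six-membered aromatic rings of carbon only give way to one, the group goes from 10 heavy atoms to 7, and fluorine enters, so the step belongs to the whole exchange and to no one of these parts. No measurement given here accounts for the step.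

The compounds shown leave open how a plain benzyl group or a longer chain ending in an amine would stand at this place, and so whether the step follows the lost ring or the added fluorine. Also open, going by these compounds, is whether the step would hold in a compound with fluoro in place of bromo on the aromatic carbon of the other benzyl group.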